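Sulfur for oxygen in the ring beside the sulfonyl

This account rests on a few compounds, and the source may have more. Where it says the series, first, only, none or still open, it means among the compounds named here.

The series rests on three measured compounds. Compound 1 `Cc1ccc(-c2c[nH]nc2S(=O)(=O)CC2=NCCS2)cc1` and compound 2 `O=S(=O)(CC1=NCCS1)C1C(c2ccc(Cl)cc2)=NN(c2ccccc2)C1c1ccc(Cl)cc1` both carry a sulfur-containing ring on the carbon bound to the sulfonyl sulfur; in a functional assay, read by Griess assay, with a stated time of 150 min, tested at 75 ug/mL (a lower number here means a weaker effect, a higher number a stronger effect of the compound at the concentration tested), compound 1 is reported as "not active" (no number reported), and compound 2 likewise as "not active" (no number reported). Compound 3 `O=S(=O)(CC1=NCCO1)C1C(c2ccccc2)=NOC1c1ccccc1` stands alone with a number: in this assay compound 3 gives 57.2%, the only figure shown among the three.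

Compound 4 `O=S(=O)(CC1=NCCS1)C1C(c2ccccc2)=NOC1c1ccccc1` is the unmeasured partner of compound 3. The change is a group of 5 heavy atoms (3 carbon, 1 nitrogen, 1 sulfur; one five-membered non-aromatic ring with 2 hetero atoms) in place of a group of 5 heavy atoms (3 carbon, 1 nitrogen, 1 oxygen; one five-membered non-aromatic ring with 2 hetero atoms), on a saturated chain carbon bound to a sulfonyl sulfur. Going by the values given here, no step between measured compounds exists to size this change, but the two compounds with the sulfur ring report no activity, so a drop beyond the scatter is expected, estimated as a number 17.2 percentage points lower from compound 3 to compound 4 (beyond the scatter). For compound 4 the expected reading is 40%, within 15% to 60%.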

Compound 4, a percentage reported as activity, at one concentration (the size of the read-out at that concentration, not a potency): "not active" (no number reported)
Nothing numeric was reported for compound 4, so the estimate cannot be set against anything.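

Going by these compounds alone, compound 4 is reported as "not active" (no number reported), so no step from compound 3 to it can be read. The compounds shown leave open how large any difference between the oxygen and sulfur rings is. No measurement shown bears on this result.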